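Hydroxyl on the lactam ring of a cytotoxic amide

The source may report more compounds than this note shows. Statements on the series, on what has been measured and on what is new or still open speak of the compounds shown alone.

In a functional assay on HL-60 cells (Homo sapiens) for cytotoxicity, read by colorimetric assay and neutral red uptake, with a stated time of 72 h (on this read-out higher numbers stand for weaker inhibition and lower numbers for stronger inhibition), compound 1 `CO[C@@H](C(=O)N[C@@H]1CCCCNC1=O)[C@H](O)[C@@H](O)[C@H](O)/C=C/C(C)(C)C` gives 5300 nM. Compound 2 `CO[C@@H](C(=O)N[C@@H]1CCCCNC1=O)[C@@H]1OC(C)(C)O[C@H](/C=C/C(C)(C)C)[C@@H]1O` reaches only the limit of the assay, > 150000 nM, and so has no number. Compound 3 `CO[C@@H](C(=O)N[C@H]1CCCCNC1=O)[C@H](O)[C@@H](O)[C@H](O)/C=C/C(C)(C)C` gives 83300 nM, the highest of the two numbers measured, and it is tied to compound 1 by a single change: a 16-fold higher number from compound 1 to compound 3 (1.20 log units; beyond the scatter), a step that rests on (the fact that compounds 1 and 3 differ only in the configuration as drawn).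

Compound 4 `CO[C@@H](C(=O)N[C@@H]1CC[C@@H](O)CNC1=O)[C@H](O)[C@@H](O)[C@H](O)/C=C/C(C)(C)C` differs from compound 3 in one place: 6-hydroxy-2-oxoazepan-3-yl in place of 2-oxoazepan-3-yl on an amide-type nitrogen. Among the compounds with values here, no measured step changes a substituent on this ring; the only step known, from compound 1 to compound 3, alters configuration alone and does not bear on adding a hydroxyl. The expectation for compound 4 is therefore set close to compound 3, with a wide margin, and the estimated step in this assay is a 1.7-fold lower number from compound 3 to compound 4 (0.22 log units; within the scatter), no direction being favoured beyond the scatter. Compound 4 is expected to give about 50000 nM in this assay, within a range from 8000 nM to 150000 nM.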

Compound 4, half-maximal inhibitory concentration: 12100 nM
The estimate for compound 4 lay 4.1-fold (0.62 log units) above the measured number; low and high end bracket the measured number.
By their numbers in this assay, from the lowest: compound 1; then compound 4; then compound 3. At a limit, above all of these: compound 2.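

Among the compounds shown, only compound 4 carries a substituent on the seven-membered ring, and in this assay hydroxy in place of hydrogen on a saturated ring carbon gives a 2.3-fold higher number from compound 1 to compound 4 (0.36 log units; beyond the scatter), a modest step that lies beyond the scatter. The 6-hydroxy-2-oxoazepan-3-yl group in place of 2-oxoazepan-3-yl gives a 6.9-fold lower number from compound 3 to compound 4 (0.84 log units; beyond the scatter), which places compound 4 between the other two measured compounds; this larger step is harder to read as the effect of the hydroxy alone, since compound 4 is drawn with the ring configuration of compound 1, not that of compound 3. Nothing at hand explains why adding this hydroxy changes the number as it does.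

The compounds shown leave open whether the configuration of the new hydroxy-bearing carbon matters, since only one arrangement of that stereocentre appears here. They also leave open whether an amine or a methoxy group on the same ring carbon would give a number closer to that of compound 1 or further from it.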